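The compounds below may be only part of what the source reports. "The series", "measured", "known", "first", "only" and "open" are said of these compounds alone.

In a functional assay on MDA-MB-231 cells (Homo sapiens) for inhibition, read by MTT assay, with a stated time of 48 h (a lower number here means a stronger inhibitor, a higher number a weaker inhibitor), compound 2 `O=C(NC1CCC1)c1[nH]cnc1-c1nc2ccccc2[nH]1` gives 33800 nM and stands level with the two other measured compounds. Compound 1 `N#Cc1ccccc1NC(=O)c1[nH]cnc1-c1nc2ccccc2[nH]1` gives 34200 nM and compound 3 `O=C(Nc1cccc2ccccc12)c1[nH]cnc1-c1nc2ccccc2[nH]1` gives 34800 nM within the usual scatter of that number. Compound 4 `O=C(NCc1ccco1)c1[nH]cnc1-c1nc2ccccc2[nH]1` differs from compound 2 by (furan-2-yl)methyl in place of cyclobutyl on an amide-type nitrogen with the shared core untouched. Among the compounds with values here, the one measured step at that nitrogen, a 1.0-fold lower number from compound 1 to compound 2 (0.01 log units; within the scatter) for cyclobutyl in place of 2-cyanophenyl, lies within the scatter, and compound 3, with another group there, gives a matching number. No step beyond the scatter is therefore expected in this assay in either direction. The estimated change, a 1.0-fold higher number from compound 2 to compound 4 (0.00 log units; within the scatter) here, stays within the scatter. For compound 4 the expected value is 34000 nM with an estimated range from 20000 nM to 58000 nM in repeat measurements.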

Compound 4, half-maximal inhibitory concentration: 22200 nM
Beside the measured number, compound 4's estimate is 1.5-fold (0.19 log units) above it; the measured number falls inside the stated range.
By their numbers in this assay, from the lowest: compounds 4, 2, 1 and 3 (each within the scatter of the next).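

In this assay, a fourth group on the amide-type nitrogen, (furan-2-yl)methyl, still gives no step beyond the scatter: a 1.5-fold lower number from compound 2 to compound 4 (0.18 log units; within the scatter) and a 1.5-fold lower number from compound 1 to compound 4 (0.19 log units; within the scatter) both stay within it. The four groups at this position, including the cyclobutyl and the furan-bearing group, therefore give numbers that cannot be told apart here. Nothing available explains this flat result. Going by these compounds, whether a longer chain, an amine or a carboxylic acid on this nitrogen would give a step beyond the scatter remains open. So does the effect of any change to the shared core.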